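Aryl hydrazones of hydroxyguanidine: methyl in place of methoxy

The source may hold more compounds than are shown below. What is called first, only, known or untested is meant among the compounds shown, and "the series" means these compounds.

Measured compounds:
compound 1, `N=C(NO)N/N=C/c1ccc(Cl)cc1`: > 100000 nM (a limit of the assay)
compound 2, `COc1ccc(/C=N/NC(=N)NO)cc1`: > 100000 nM (a limit of the assay)

In a functional assay on HL-60 cells (Homo sapiens) for antiproliferative activity (a higher number here means a weaker inhibitor, a lower number a stronger inhibitor), compound 1 gives only a limit, > 100000 nM. In this assay compound 2 likewise gives only a limit, > 100000 nM. The step between them, a step that the two limits leave unreadable from compound 1 to compound 2, is therefore not readable, and what the two values show is the limit of > 100000 nM in this assay, at which 2 of the 2 values shown sit. Compound 3, `Cc1ccc(/C=N/NC(=N)NO)cc1`, carries the change (methyl in place of methoxy on an aromatic carbon). For the measured compounds named here, the only measured step that bears on it is the one from compound 1 to compound 2, and its size is hidden behind the two limits, so it gives no sign of direction. Compound 3 is thus expected to sit at the same limit, with an expected step that the limit leaves unreadable from compound 2 to compound 3 that cannot be told apart from none. The estimate for compound 3 is 150000 nM, with a range from 50000 nM to 500000 nM.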

Compound 3, half-maximal inhibitory concentration: 67000 nM
Compound 3: middle estimate off by 2.2-fold (0.35 log units), on the high side, and the stated range covers the measured number.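

In this assay, for the compounds shown here, compound 3, with methyl on the aromatic carbon para to a group of 7 heavy atoms, gives 67000 nM, the only one of the three values that is a number and not a limit. This position therefore admits a readable value, and the change of methoxy to methyl is an at least 1.4-fold lower number from compound 2 to compound 3 (0.17 log units; that floor lies within the scatter), while the change of chloro to methyl is an at least 1.4-fold lower number from compound 1 to compound 3 (0.17 log units; that floor lies within the scatter). Both steps are only floors, so their true size stays hidden, and the floors themselves do not go beyond the scatter, for a single reason: the limit of > 100000 nM in this assay, at which 2 of the 3 values shown sit.

The compounds shown leave open how far methoxy and chloro truly lie from methyl. They also leave open how an amine, a carboxylic acid or a longer chain such as ethyl on this carbon would read in this assay.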